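From 4-methylpiperazin-1-yl to piperazin-1-yl on compound 2

The compounds below may be only part of what the source reports. "The series", "measured", "known", "first", "only" and "open" are said of these compounds alone.

Of the compounds shown here, three have so far been measured in an ADME assay on a cell-free system (plasma, Homo sapiens) for protein binding, on two cores. Compound 1 (`Cc1cn2cc(-c3cc4ccc(N5CCN(C)CC5)cc4c(=O)o3)nc2c(C)n1`) gives 93% and compound 3 (`Cc1cn2cc(-c3cc4ccc(N5CCNCC5)cc4c(=O)o3)nc2c(C)n1`) gives 90% on one core, while compound 2 (`Cc1cn2nc(-c3cc(=O)n4cc(N5CCN(C)CC5)ccc4n3)cc2c(C)n1`) gives 80% on the other. Compound 2 leaves more compound free than compound 1, a gap beyond the scatter, while its gap to compound 3 lies within the scatter.

Compound 4 (`Cc1cn2nc(-c3cc(=O)n4cc(N5CCNCC5)ccc4n3)cc2c(C)n1`) keeps the core of compound 2 and carries hydrogen in place of methyl on an amine nitrogen in a ring, so that 4-methylpiperazin-1-yl becomes piperazin-1-yl. Among the measured compounds shown here, the same change has been measured only once, as a 1.4-fold higher unbound fraction from compound 1 to compound 3 (0.15 log units; within the scatter) on the core of compound 1, and no such pair exists yet on the core of compound 2. For the measured compounds named here, that single step is the only guide, so a change of similar size and direction is expected in this assay and it should stay within the scatter. The expected step is a 1.4-fold higher unbound fraction from compound 2 to compound 4 (0.13 log units; within the scatter) as estimated here. For compound 4 the estimated value is 73% (expected range 60% to 84%).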

Compound 4, plasma protein binding: 70%
Compound 4: middle estimate off by 1.1-fold (0.05 log units) (unbound fraction), on the low side; the measured number falls inside the stated range.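

In this assay hydrogen in place of methyl on an amine nitrogen in a ring, 4-methylpiperazin-1-yl to piperazin-1-yl, gives a 1.5-fold higher unbound fraction from compound 2 to compound 4 (0.18 log units; within the scatter) on the core of compound 2, so this change no longer rests on a single pair. Neither step alone lies beyond the scatter, so neither establishes a real effect at this position on its own. What the series adds is agreement between two cores, with the change reading much the same on both: the same change on two cores in this assay, a 1.4-fold higher unbound fraction (0.15 log units; within the scatter) from compound 1 to compound 3 and a 1.5-fold higher unbound fraction (0.18 log units; within the scatter) from compound 2 to compound 4, 1.1-fold (0.02 log units) apart, within the scatter of two such steps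

The compounds shown carry only methyl or hydrogen on this nitrogen, so it remains open how this assay responds to a longer chain such as ethyl or to an acetyl group there. Going by these compounds, with two cores in hand, it also remains open whether the same agreement would hold on any further core.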